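A few compounds are considered here, and "the series" means these few. Any claim that something is new, unique, unknown or untested is made for them only; others in the source may bear on it.

Among the compounds with values here, compound 3 `COc1cc(-c2nn(-c3cccc(NC(=O)Nc4ccc(Cl)c(C(F)(F)F)c4)c3)cc2-c2ccncc2)ccc1Cl` gives 1290 nM in a functional assay on SW-620 cells (Homo sapiens) for inhibition, read by sulforhodamine B assay, with a stated time of 48 h (on this read-out higher numbers stand for weaker inhibition of growth and lower numbers for stronger inhibition of growth), the lowest of the three numbers measured so far. Its nearest neighbour is compound 2 `O=C(Nc1cccc(-n2cc(-c3ccncc3)c(-c3ccc(Cl)c(O)c3)n2)c1)Nc1ccc(Cl)c(Cl)c1`, which in this assay gives 1460 nM, a gap that lies within the scatter; the furthest is compound 1 `O=C(Nc1cccc(-n2cc(-c3ccncc3)c(-c3ccc(Cl)c(O)c3)n2)c1)Nc1cccc(C(F)(F)F)c1`, which gives 3830 nM, a gap beyond the scatter. Within the data shown here, the one step measured between neighbours, a 2.6-fold lower number from compound 1 to compound 2 (0.42 log units; beyond the scatter), concerns a change on the urea end and not the change now at hand.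

Compound 4 `O=C(Nc1cccc(-n2cc(-c3ccncc3)c(-c3ccc(Cl)c(O)c3)n2)c1)Nc1ccc(Cl)c(C(F)(F)F)c1` differs from compound 3 by hydrogen in place of methyl on an oxygen on an aromatic ring. Among the measured compounds shown here, no measured pair shows this change directly; the only guide is that compound 2, which carries the hydroxy group, stands within the scatter of compound 3. On that basis the step of a 1.1-fold higher number from compound 3 to compound 4 (0.04 log units; within the scatter) is expected to be small, with no clear direction beyond the scatter. Compound 4 is therefore estimated at 1400 nM in this assay, within a range from 500 nM to 4000 nM.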

Compound 4, concentration for 50% growth inhibition: 1150 nM
Estimate against measurement, compound 4: 1.2-fold (0.09 log units) above; low and high end bracket the measured number.
By their numbers in this assay, from the lowest: compounds 4, 3 and 2 (each within the scatter of the next); then compound 1.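

In this assay, the methoxy to hydroxy change on the oxygen of the aromatic ring now has a direct reading, a 1.1-fold lower number from compound 3 to compound 4 (0.05 log units; within the scatter), and this step lies within the scatter, so the two groups cannot be told apart here. Within the data shown here, the other end of the molecule adds two readings: trifluoromethyl in place of chloro gives a 1.3-fold lower number from compound 2 to compound 4 (0.10 log units; within the scatter), also within the scatter, whereas chloro in place of hydrogen gives a 3.3-fold lower number from compound 1 to compound 4 (0.52 log units; beyond the scatter), the only one of the new steps beyond the scatter. Nothing available explains why these changes differ in size.

This single pair leaves open whether methoxy and hydroxy would also match alongside other groups at the far end of the molecule. It also leaves open how a longer chain such as ethoxy, or an amine in place of the hydroxy, would read in this assay.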